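The source may hold more compounds than are shown below. What is called first, only, known or untested is meant among the compounds shown, and "the series" means these compounds.

Compounds measured so far:
- compound 1, `C[C@@H](O)Cc1cc(-c2ccnc3[nH]nc(C(F)(F)F)c23)cc(C2(C#N)CC2)c1`: 34 nM
- compound 2, `CC(C)C(O)Cc1cc(-c2ccnc3[nH]nc(C(F)(F)F)c23)cc(C2(C#N)CC2)c1`: 215 nM

Both were tested in an assay on isolated protein for inhibition of protein kinase C epsilon type (Homo sapiens), read by coupled enzyme assay; on this read-out higher numbers stand for weaker inhibition and lower numbers for stronger inhibition. Within the data shown here, compound 2 gives the higher of the two numbers: the one step that joins it to a measured neighbour, a 6.3-fold higher number from compound 1 to compound 2 (0.80 log units; beyond the scatter), shows that exchanging the smaller group on the carbon bearing the hydroxyl for the larger branched one cost potency.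

Compound 3, `N#CC1(c2cc(CC(O)C3CC3)cc(-c3ccnc4[nH]nc(C(F)(F)F)c34)c2)CC1`, differs from compound 2 in a single place: cyclopropyl in place of isopropyl on a saturated chain carbon bound to an oxygen on a saturated carbon and a saturated chain carbon. The group that enters has the same count of heavy atoms as the one that leaves, but is closed into a ring. Among the measured compounds shown here, the only measured step that bears on this position is the one from compound 1 to compound 2, and it tells that the open, branched group at this carbon sits well above the smallest group tested. A cyclopropyl is neither of these, so compound 3 is expected to land between the two measured values, with a drop relative to compound 2 of about a 2.2-fold lower number from compound 2 to compound 3 (0.33 log units; beyond the scatter). Compound 3 is thus estimated at 100 nM, within a range from 40 nM to 300 nM.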

Compound 3, inhibition constant: 30 nM
The estimate for compound 3 lay 3.3-fold (0.52 log units) above the measured number, and the stated range ends above it.
By their numbers in this assay, from the lowest: compounds 3 and 1 (each within the scatter of the next); then compound 2.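

In this assay, the step of a 7.2-fold lower number from compound 2 to compound 3 (0.86 log units; beyond the scatter) shows that at this carbon the number does not follow the count of heavy atoms: isopropyl and cyclopropyl have the same count and differ in that cyclopropyl is closed into a ring. The step of a 1.1-fold lower number from compound 1 to compound 3 (0.05 log units; within the scatter) gives no difference to read between cyclopropyl(hydroxy)methyl and 1-hydroxyethyl, so the loss of potency seen with the open, branched group in compound 2 does not extend to the ring in compound 3, and a larger group here does not by itself mean a higher number. No measurement is at hand that accounts for the gap between the open group and the ring.

Three groups on one carbon cannot show whether the tolerance for the ring extends to a cyclobutyl, or whether a tert-butyl would fall further than isopropyl. Also open, as far as these compounds go, is the configuration at the carbon bearing the hydroxyl, which is drawn as defined only in compound 1, so these comparisons cannot say how much of the steps belongs to the group and how much to that configuration.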